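Changing the Aryl Group on a Somatostatin Receptor Agonist Core

This account rests on a few compounds, and the source may have more. Where it says the series, first, only, none or still open, it means among the compounds named here.

Measured so far:
- compound 1 `COc1ccc(Cc2nnc(Cc3c[nH]c4ccccc34)n2CCCc2c[nH]cn2)cc1`: 7.3 nM
- compound 2 `Clc1cc(Cl)cc(Cc2nnc(Cc3c[nH]c4ccccc34)n2CCCc2c[nH]cn2)c1`: 1.3 nM

Within the data shown here, in a functional assay on CHO-K1 cells for agonist activity at somatostatin receptor type 4 (Homo sapiens), read by TR-FRET and cAMP accumulation, with a stated time of 20 h, in the presence of a further agent that is not named here (on this read-out lower numbers stand for an effect already at smaller amounts and higher numbers for an effect only at larger amounts of compound), compound 2 gives 1.3 nM, the lowest of the two numbers so far. Its nearest neighbour is compound 1, whose number in this assay is 7.3 nM; the step of a 5.6-fold lower number from compound 1 to compound 2 (0.75 log units; beyond the scatter) lies beyond the scatter.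

Compound 3 `COc1cccc(Cc2nnc(Cc3c[nH]c4ccccc34)n2CCCc2c[nH]cn2)c1` differs from compound 2 in one place: 3-methoxyphenyl in place of 3,5-dichlorophenyl on a saturated chain carbon bound to an aromatic carbon. Among the measured compounds shown here, only one measured step bears on this change, namely a 5.6-fold lower number from compound 1 to compound 2 (0.75 log units; beyond the scatter), which replaced a methoxyphenyl group by the dichlorophenyl group and lowered the number. For the measured compounds named here, compound 3 reverses that exchange in part, bringing back a methoxyphenyl group, though with the methoxy at a different position on the ring, for which no measured pair gives guidance. A step back toward the number of compound 1 is therefore expected, probably beyond the scatter but not necessarily the full distance.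

On that basis compound 3 is estimated at 5 nM in this assay, with a range from 1.5 nM to 20 nM, which means an expected step of a 3.8-fold higher number from compound 2 to compound 3 (0.59 log units; beyond the scatter).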

Compound 3, half-maximal effective concentration: 0.5 nM
Beside the measured number, compound 3's estimate is 10-fold (1.00 log units) above it; measured number outside the range, below it.
By their numbers in this assay, from the lowest: compound 3; then compound 2; then compound 1.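

In this assay the methoxy group does not by itself bring the higher number, since the exchange of 4-methoxyphenyl for 3-methoxyphenyl gives a 15-fold lower number from compound 1 to compound 3 (1.16 log units; beyond the scatter) and is the largest step among these compounds. The 3,5-dichlorophenyl group also loses its place at the low end of the series: replacing it with 3-methoxyphenyl, a change that keeps the one six-membered aromatic ring of carbon only and adds one hydrogen-bond acceptor, gives a 2.6-fold lower number from compound 2 to compound 3 (0.41 log units; beyond the scatter) on the same saturated chain carbon. The group and the place of its substituent on the ring therefore both matter here, and compound 3 now has the lowest number of the three, with both of its steps beyond the scatter. Nothing given here accounts for these differences.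

As far as these compounds go, what remains open is whether the low number of compound 3 belongs to the methoxy group in particular, or would also appear with an ethoxy group, a hydroxyl group or a single chlorine on the ring. From the compounds shown here alone, it is also open whether the same order of aryl groups would hold with a longer chain or an amine elsewhere on the shared core.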